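The compounds below may be only part of what the source reports. "The series", "measured", "known", "first", "only" and "open" are said of these compounds alone.

Measured so far: compound 1 `Cc1nn(Cc2ccccc2C(N)=O)c(C)c1NC(=O)c1ccc(COc2ccccc2)cc1` with 42000 nM in a functional assay on MIA PaCa-2 cells (Homo sapiens) for antiproliferative activity, read by MTT assay, with a stated time of 72 h; on this read-out higher numbers stand for an effect only at larger amounts of compound and lower numbers for an effect already at smaller amounts; compound 2 `Cc1nn(Cc2cccc(C(=O)N(C)C)c2)c(C)c1NC(=O)c1ccc(COc2ccccc2)cc1` with 6400 nM; compound 3 `CNC(=O)c1cccc(Cn2nc(C)c(NC(=O)c3ccc(COc4cccc(C)c4)cc3)c2C)c1` with 6200 nM.

Compound 3 has the lowest number of the three, though compound 2 sits within the scatter of it; only compound 1 stands clearly apart. Compound 4 `CNC(=O)c1cccc(Cn2nc(C)c(NC(=O)c3ccc(COc4ccc(C(F)(F)F)cc4)cc3)c2C)c1` differs from compound 3 by 4-(trifluoromethyl)phenyl in place of 3-methylphenyl on an oxygen on a saturated carbon. Going by the values given here, the one measured step, a 6.6-fold lower number from compound 1 to compound 2 (0.82 log units; beyond the scatter), concerns the other end of the molecule and does not touch the phenoxy side. Compounds 2 and 3 differ in two places at once, so their near-equal values give no isolated reading on the phenoxy ring. With nothing bearing directly on the change, compound 4 is expected to show no step beyond the scatter, a 1.0-fold lower number from compound 3 to compound 4 (0.01 log units; within the scatter). Compound 4 is therefore estimated at 6000 nM, within 2500 nM to 15000 nM.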

Compound 4, half-maximal effective concentration: 800 nM
Beside the measured number, compound 4's estimate is 7.5-fold (0.88 log units) above it, and the stated range ends above it.
By their numbers in this assay, from the lowest: compound 4; then compounds 3 and 2 (each within the scatter of the next); then compound 1.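

Setting 4-(trifluoromethyl)phenyl in place of 3-methylphenyl on an oxygen on a saturated carbon gives a 7.8-fold lower number from compound 3 to compound 4 (0.89 log units; beyond the scatter) in this assay, so this end of the molecule, untouched by the earlier single step, can shift the number beyond the scatter. The change alters both the substituent and where it sits on the ring, and the step cannot be assigned to either alone. No measurement shown here accounts for the step. Still open, from the compounds shown here alone, is whether 4-methylphenyl or 3-(trifluoromethyl)phenyl would separate those two contributions, and how 4-chlorophenyl or 4-methoxyphenyl would compare in this place.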